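Swapping the 2-methoxyphenyl group of compound 1

The source may report more compounds than this note shows. Statements on the series, on what has been measured and on what is new or still open speak of the compounds shown alone.

Compound 1 `COc1ccccc1/C=C(/SCc1ccc(F)cc1)C(=O)c1ccc(Br)cc1` gives 10000 nM in a functional assay on DU-145 cells (Homo sapiens) for inhibition, read by trypan blue exclusion, with a stated time of 96 h; a lower number here means a stronger inhibitor of growth, a higher number a weaker inhibitor of growth. Compound 2 `COc1ccccc1/C=C(/SCc1ccc(F)cc1)C(=O)c1ccc(Cl)cc1` gives 10000 nM there, and compound 3 `O=C(/C(=C\c1ccccc1OCc1ccccc1)SCc1ccc(F)cc1)c1ccc(Br)cc1` gives 1000 nM. Compound 1 therefore shares the highest number of the three with compound 2, which places this pair at the weak end of a very small set.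

Compound 4 `Cc1ccc(C)c(/C=C(/SCc2ccc(F)cc2)C(=O)c2ccc(Br)cc2)c1` keeps the rest of compound 1 and carries 2,5-dimethylphenyl in place of 2-methoxyphenyl on a double-bonded chain carbon bound to a double-bonded chain carbon.

Within the data shown here, no measured step makes this exact swap. The step of no change at the digits printed from compound 1 to compound 2 (within the scatter) lies within the scatter, but it concerns a different group, chloro in place of bromo. The step of a 10-fold lower number from compound 1 to compound 3 (1.00 log units; beyond the scatter) is modest and beyond the scatter, and it does alter the methoxy group that leaves in compound 4, by phenyl in place of hydrogen. Yet no such phenyl enters here, so that step cannot simply be carried over. Only a slight fall in the number is expected, with the estimated step of a 1.7-fold lower number from compound 1 to compound 4 (0.22 log units; within the scatter) staying within the scatter. For compound 4 the estimate is 6000 nM, with an expected range from 2000 nM to 15000 nM.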

Compound 4, concentration for 50% growth inhibition: 1000 nM
Estimate against measurement, compound 4: 6.0-fold (0.78 log units) above; the measured number lies below the stated range.
By their numbers in this assay, from the lowest: compounds 3 and 4 (each within the scatter of the next); then compounds 1 and 2 (each within the scatter of the next).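

In this assay, the step of a 10-fold lower number from compound 1 to compound 4 (1.00 log units; beyond the scatter) shows that this position can give a change beyond the scatter without the extra phenyl that separates compound 3 from compound 1: compound 3 gives 1000 nM and compound 4 gives 1000 nM, the same printed number from two different groups. The group that leaves and the group that enters have the same count of heavy atoms and each holds one six-membered aromatic ring of carbon only, so a larger heavy-atom count is not needed for this step. The swap does, however, make two changes at once, since the oxygen is lost and 2,5-dimethylphenyl carries two methyl groups, and this single step cannot divide its size between them.

The compounds shown leave open how a group such as 2-methylphenyl, 2-hydroxyphenyl or a phenyl bearing an amine would fare at this position, and whether the step holds with chloro in place of bromo. Nothing available here accounts for the size of this step.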